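Swapping hydroxy and methoxy on the hydrazone aryl group

The source may report more compounds than this note shows. Statements on the series, on what has been measured and on what is new or still open speak of the compounds shown alone.

Of the compounds shown here, three sharing one core have been measured in a functional assay on HT-29 cells (Homo sapiens) for cytotoxicity, read by MTT assay, with a stated time of 72 h; on this read-out higher numbers stand for weaker inhibition and lower numbers for stronger inhibition. Compound 1 `CN(C)CCn1cnnc1-c1cc(Oc2ccc(NC(=O)N/N=C/c3cccc(O)c3)cc2F)ccn1` gives 330 nM. Compound 2 `CN(C)CCn1cnnc1-c1cc(Oc2ccc(NC(=O)N/N=C/c3cc(Br)c(O)c(Br)c3)cc2F)ccn1` gives 2670 nM. Compound 3 `COc1ccc(/C=N/NC(=O)Nc2ccc(Oc3ccnc(-c4nncn4CCN(C)C)c3)c(F)c2)cc1O` gives 960 nM, which is the second highest of the three numbers: compound 2 sits nearer to it, as a 2.8-fold lower number from compound 2 to compound 3 (0.44 log units; beyond the scatter) shows, while compound 1 lies further away, as a 2.9-fold higher number from compound 1 to compound 3 (0.46 log units; beyond the scatter) shows.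

Compound 4 `COc1cc(/C=N/NC(=O)Nc2ccc(Oc3ccnc(-c4nncn4CCN(C)C)c3)c(F)c2)ccc1O` differs from compound 3 only in how the same atoms are joined: 4-hydroxy-3-methoxyphenyl in place of 3-hydroxy-4-methoxyphenyl on a carbon with a double bond to nitrogen.

Among the measured compounds shown here, no measured step swaps these two groups, so the bearing of the earlier steps is indirect. Adding a methoxy group gave a 2.9-fold higher number from compound 1 to compound 3 (0.46 log units; beyond the scatter), and replacing the aryl group wholesale gave an 8.1-fold higher number from compound 1 to compound 2 (0.91 log units; beyond the scatter), both modest. With the same donor and acceptor count retained in compound 4, the step of a 1.1-fold lower number from compound 3 to compound 4 (0.03 log units; within the scatter) in this assay is expected to stay within the scatter. Compound 4 is therefore estimated at 900 nM, with a range from 400 nM to 2200 nM.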

Compound 4, half-maximal inhibitory concentration: 120 nM
Compound 4: middle estimate off by 7.5-fold (0.88 log units), on the high side; measured number outside the range, below it.
By their numbers in this assay, from the lowest: compound 4; then compound 1; then compound 3; then compound 2.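

Exchanging the hydroxy and methoxy groups on the aryl ring, with the atoms and the donor and acceptor counts unchanged, gives an 8.0-fold lower number from compound 3 to compound 4 (0.90 log units; beyond the scatter) in this assay, so at this place the arrangement of the two groups matters and not just their presence. The 4-hydroxy-3-methoxyphenyl group also gives a 2.8-fold lower number from compound 1 to compound 4 (0.44 log units; beyond the scatter) and a 22-fold lower number from compound 2 to compound 4 (1.35 log units; beyond the scatter), which makes compound 4 the most potent of the four and shows that a methoxy group here can go with a lower number as well as the higher one seen for compound 3. Nothing available here explains why this arrangement gives the lower number.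

As far as these compounds go, what a 3,4-dimethoxyphenyl or a 4-hydroxyphenyl group would give at this place remains open, so the separate roles of the hydroxy and the methoxy are unresolved.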